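Working notes: aryl ring variation and anticonvulsant dose

The compounds below may be only part of what the source reports. "The series", "measured", "known", "first", "only" and "open" are said of these compounds alone.

compound 1 `CC1(c2ccccc2)CC(=O)N(CC(=O)N2CCN(c3ccc(F)cc3)CC2)C1=O` — 100 mg/kg
compound 2 `CC1(c2ccccc2)CC(=O)N(CC(=O)N2CCN(c3cccc(Cl)c3)CC2)C1=O` — 300 mg/kg
compound 3 `CC1(c2ccccc2)CC(=O)N(CC(=O)N2CCN(c3cccc(Cl)c3Cl)CC2)C1=O` — "not active" (no number reported)

All three were tested in a functional assay on the whole organism (strain CD-1) with Mus musculus as the target, in the maximal electroshock model, with a stated time of 0.5 h; a lower number here means that less compound is needed, a higher number that more compound is needed for the effect. Compound 1 shows the lowest of the two numbers reported; its nearest neighbour is compound 2, and the step of a 3.0-fold higher number from compound 1 to compound 2 (0.48 log units; beyond the scatter) lies beyond the scatter. Compound 3 gave no number in this assay and is reported only as inactive.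

Compound 4 `CC1(c2ccccc2)CC(=O)N(CC(=O)N2CCN(c3ccc(Cl)c(Cl)c3)CC2)C1=O` has not yet been measured. Its difference from compound 1 is 3,4-dichlorophenyl in place of 4-fluorophenyl on an amine nitrogen in a ring. For the measured compounds named here, the one measured step that bears on this change is a 3.0-fold higher number from compound 1 to compound 2 (0.48 log units; beyond the scatter), a modest rise in dose on going from a fluorine-bearing to a chlorine-bearing ring on the amine nitrogen in a ring; compound 3, which carries two chlorines on that ring, gave no number at all. A rise beyond the scatter in this assay is therefore expected for compound 4, with a real chance that only inactivity is reported rather than a dose. For compound 4 the expected step is a 3.0-fold higher number from compound 1 to compound 4 (0.48 log units; beyond the scatter). Compound 4 is estimated at 300 mg/kg, with a range from 100 mg/kg to 600 mg/kg.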

Compound 4, minimum effective dose: "not active" (no number reported)
The entry for compound 4 holds no number; the estimate stays without a comparison.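

For the compounds shown here, compound 4, like compound 3, is reported as not active in this assay without a number, and no new step from compound 1 can be read. The compounds shown leave open how far compound 4 lies from compound 1 on the dose scale. No supporting evidence bears on this result.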